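A few compounds are considered here, and "the series" means these few. Any claim that something is new, unique, unknown or untested is made for them only; others in the source may bear on it.

Half-life in an ADME assay on the whole organism (strain CD-1) for metabolic stability, with Mus musculus as the target, at a dose of 3 mg/kg by the intravenous route; on this read-out lower numbers stand for a shorter-lived compound and higher numbers for a longer-lived compound:

- compound 1 `C[C@H](CCCOc1ccccc1CN(C)C(=O)c1ccc(-c2ccco2)cc1)CC(=O)O`: 3.9 h
- compound 2 `CN(Cc1ccccc1OCCC[C@@H]1C[C@@H]1C(=O)O)C(=O)c1ccc(-c2ccco2)cc1`: 2.7 h
- compound 3 `CN(Cc1ccccc1OCCC[C@@H]1C[C@H]1C(=O)O)C(=O)c1ccc(-c2ccco2)cc1`: 3.5 h

At 3.5 h, compound 3 lies within the scatter of both other compounds, so the three values form no order. Next in the series is compound 4 `C/C(=C\C(=O)O)CCCOc1ccccc1CN(C)C(=O)c1ccc(-c2ccco2)cc1`, which has not yet been measured in this assay. The change is 2-carboxy-1-methylethenyl in place of 2-carboxycyclopropyl on a saturated chain carbon, three bonds along the chain from an oxygen on an aromatic ring. In words, 2-carboxy-1-methylethenyl replaces 2-carboxycyclopropyl on a saturated chain carbon, three bonds along the chain from an oxygen on an aromatic ring.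

The closest measured exchange at this place is a 1.1-fold lower number from compound 1 to compound 3 (0.05 log units; within the scatter), where 2-carboxycyclopropyl replaces 1-(carboxymethyl)ethyl. The same exchange with the other drawn configuration is a 1.4-fold lower number from compound 1 to compound 2 (0.16 log units; within the scatter). The configurational pair gives a 1.3-fold higher number from compound 2 to compound 3 (0.11 log units; within the scatter). Among the compounds with values here, none of these steps exceeds the scatter, although no measured compound yet carries 2-carboxy-1-methylethenyl, so this remains an extrapolation. No shift beyond the scatter is therefore expected, and the expected change is a 1.1-fold lower number from compound 3 to compound 4 (0.03 log units; within the scatter), with no direction favoured. The expected half-life of compound 4 is 3.3 h, with an estimated range of 1.7 h to 6.4 h.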

Compound 4, half-life: 1.6 h
For compound 4 the middle estimate is 2.1-fold (0.31 log units) above the measured one; measured number outside the range, below it.
By their numbers in this assay, from the lowest: compounds 4, 2, 3 and 1 (each within the scatter of the next, the first and the last beyond it).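

In this assay, within the data shown here, 2-carboxy-1-methylethenyl is the first group at this saturated chain carbon, three bonds along the chain from an oxygen on an aromatic ring, to give steps beyond the scatter: a 2.2-fold lower number from compound 3 to compound 4 (0.34 log units; beyond the scatter), and a 2.4-fold lower number from compound 1 to compound 4 (0.39 log units; beyond the scatter), both modest. Loss of the ring alone does not account for this, since compound 1 carries the open-chain 1-(carboxymethyl)ethyl and its value stays within the scatter of both compounds with 2-carboxycyclopropyl, so the separation appears only with the open-chain group that has the extra double bond. The exchange does not read the same from both compounds with 2-carboxycyclopropyl, as a 1.7-fold lower number from compound 2 to compound 4 (0.23 log units; within the scatter) stays within the scatter, and this split arises from a pair with a single difference: the fact that compounds 2 and 3 differ only in the configuration as drawn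

Still open, from the compounds shown here alone, is whether the separation follows the double bond as such or its drawn geometry, which the opposite alkene isomer would address. Going by these compounds, it is also open whether the separation holds with a longer chain between the oxygen and the 2-carboxy-1-methylethenyl group, or with a primary amide in place of the carboxylic acid.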